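From ethoxy to morpholin-4-yl on a carbonyl carbon

A few compounds are considered here, and "the series" means these few. Any claim that something is new, unique, unknown or untested is made for them only; others in the source may bear on it.

In a physicochemical assay for lipophilicity, read by HPLC, with a stated time of 90 min, tested at 100 uM (on this read-out higher numbers stand for higher lipophilicity and lower numbers for lower lipophilicity), compound 2 (`CCOC(=O)N1CCC(NC(=O)Nc2ccc(OC(F)(F)F)c(F)c2)CC1`) stands highest of three measured compounds (5.94). Compound 3 (`CCOC(=O)N1CCC(NC(=O)Nc2ccc(C(F)(F)F)c(F)c2)CC1`) gives 5.46 on the same scale, and compound 1 (`Cc1occc1C(=O)N1CCC(NC(=O)Nc2ccc(C(F)(F)F)cc2)CC1`) gives 4.19 on it. Compound 4 (`O=C(Nc1ccc(OC(F)(F)F)c(F)c1)NC1CCN(C(=O)N2CCOCC2)CC1`) has no number yet. It departs from compound 2 in one place, with morpholin-4-yl in place of ethoxy on a carbonyl carbon.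

Going by the values given here, no measured step covers this exchange. Among the compounds with values here, the one single-place step available (a number 0.48 log units lower from compound 2 to compound 3 (beyond the scatter)) lies on an aromatic carbon, so it shows only how large a one-place change has been in this small set. Compound 1 carries neither ethoxy nor morpholin-4-yl on its carbonyl carbon and also differs elsewhere, so its low reading (4.19) is no more than a loose hint of direction. In this assay a fall larger than that aromatic step, and beyond the scatter, is therefore expected (a number 1.04 log units lower from compound 2 to compound 4 (beyond the scatter)). Compound 4 is estimated at 4.9 with an expected range from 4.3 to 5.5 on this scale.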

Compound 4, partition coefficient: 3.93
For compound 4 the middle estimate is 0.97 log units above the measured one; the whole stated range lies above it.
By their numbers in this assay, from the lowest: compounds 4 and 1 (each within the scatter of the next); then compound 3; then compound 2.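

Going by these compounds alone, the exchange of morpholin-4-yl for ethoxy gives a number 2.01 log units lower from compound 2 to compound 4 (beyond the scatter) in this assay and is the first measured step on a carbonyl carbon whose other neighbour is an amide-type nitrogen in a ring. Within the data shown here, this step is larger than the only other single-place step, a number 0.48 log units lower from compound 2 to compound 3 (beyond the scatter) on an aromatic carbon, so in this small set the carbonyl carbon carries the bigger change. Nothing measured here accounts for the size of this fall, which stands as an observation only.

On these data alone, whether the same exchange would move the reading as far with trifluoromethyl on the aromatic carbon, as in compound 3, stays open. Also open, as far as these compounds go, is how piperidin-1-yl, dimethylamino or a longer chain such as butoxy would read on the same carbonyl carbon, which would help separate the ring from its oxygen.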